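The compounds below may be only part of what the source reports. "The series", "measured", "known", "first", "only" and "open" are said of these compounds alone.

In an ADME assay on the whole organism (strain FVB) for pharmacokinetics, with Mus musculus as the target, read by LC-MS, at a dose of 30 mg/kg by the oral route (a lower number here means less compound in the circulation, a higher number more compound in the circulation at the dose given), compound 1 (`c1cc([C@H]2CC[C@]3(CC2)OOC2(O3)C3CC4CC(C3)CC2C4)ccc1OCCOC1CCNCC1`) gives 633 nM and compound 2 (`CC(C)(N)CCOc1ccc([C@H]2CC[C@]3(CC2)OOC2(O3)C3CC4CC(C3)CC2C4)cc1`) gives 1050 nM on the same core. Going by the values given here, these are the only two numbers available, and they cannot be told apart. The exchange of (piperidin-4-yl)oxy for 1-amino-1-methylethyl on the chain amounts to a 1.7-fold higher number from compound 1 to compound 2 (0.22 log units; within the scatter) and so gives compound 2 no real separation from compound 1.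

Compound 3 (`c1cc([C@H]2CC[C@]3(CC2)OOC2(O3)C3CC4CC(C3)CC2C4)ccc1OCCC1CCNCC1`) is now to be compared with compound 2. It has piperidin-4-yl in place of 1-amino-1-methylethyl on a saturated chain carbon, two bonds along the chain from an oxygen on an aromatic ring. Among the compounds with values here, the one measured step that bears on this change also links the 1-amino-1-methylethyl group with a group holding a piperidine ring, though that group also carries an oxygen, and it stayed within the scatter. A single small step is thin evidence, but it gives no ground to expect a large move in this assay. The expected result is a 1.3-fold lower number from compound 2 to compound 3 (0.12 log units; within the scatter) and thus no change beyond the scatter. For compound 3 the estimated maximal plasma concentration is 800 nM with an expected range of 330 nM to 1900 nM at the same oral dose.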

Compound 3, maximal plasma concentration: 1190 nM
The estimate for compound 3 lay 1.5-fold (0.17 log units) below the measured number; measured number inside the range.
By their numbers in this assay, from the lowest: compounds 1, 2 and 3 (each within the scatter of the next).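

In this assay the open 1-amino-1-methylethyl group gives way to the piperidin-4-yl ring on a saturated chain carbon, two bonds along the chain from an oxygen on an aromatic ring, and the result is a 1.1-fold higher number from compound 2 to compound 3 (0.05 log units; within the scatter) and so no separation between the two. The second comparison isolates something the first pair could not: with piperidin-4-yl in place of (piperidin-4-yl)oxy there is a 1.9-fold higher number from compound 1 to compound 3 (0.27 log units; within the scatter) and so the oxygen in that chain can also be absent without a step beyond the scatter, which leaves all three groups at this position indistinguishable by maximal plasma concentration at this oral dose. Nothing available here accounts for this flat picture.

All three groups shown carry a nitrogen, so it remains open whether a group without one, such as a cyclohexyl ring, or a carboxylic acid at the same place, would stay level with them. Going by these compounds, it is equally open whether a methyl on the piperidine nitrogen or a longer chain between the aromatic oxygen and the ring would move the number beyond the scatter.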